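Trifluoromethyl in place of fluoro in compound 3

The compounds below may be only part of what the source reports. "The series", "measured", "known", "first", "only" and "open" are said of these compounds alone.

In a functional assay on HepG2 cells (Homo sapiens) for antiproliferative activity, read by MTT assay, with a stated time of 24 h (a higher number here means a weaker inhibitor, a lower number a stronger inhibitor), compound 1 `COc1cc(OC)c(-c2coc3cc(OCC=C(C)C)ccc3c2=O)cc1OC` gives 280 nM and compound 2 `COc1cc(OC)c(-c2coc3cc(OCc4cccc(F)c4)ccc3c2=O)cc1OC` gives 1230 nM. Compound 2 therefore holds the higher number of the two, which makes it the weaker inhibitor of this pair. Compound 3 `COc1cc(OC)c(-c2coc3cc(OCc4cccc(C(F)(F)F)c4)ccc3c2=O)cc1OC` differs from compound 2 in one place, with trifluoromethyl in place of fluoro on an aromatic carbon, meta to a large group: trifluoromethyl in place of fluoro on an aromatic carbon. Among the compounds with values here, only one measured step bears on this change, a 4.4-fold higher number from compound 1 to compound 2 (0.64 log units; beyond the scatter). That modest step swapped a whole 2-methylprop-1-en-1-yl for 3-fluorophenyl, so it shows that this region can move the number but gives no direct reading on a change made on the ring itself. No step beyond the scatter is therefore expected in this assay, and neither direction is favoured. The expected change is a 1.0-fold lower number from compound 2 to compound 3 (0.01 log units; within the scatter). For compound 3 the estimated value is 1200 nM, with an expected range of 500 nM to 2900 nM.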

Compound 3, half-maximal inhibitory concentration: 610 nM
Estimate against measurement, compound 3: 2.0-fold (0.29 log units) above; the measured number falls inside the stated range.
By their numbers in this assay, from the lowest: compound 1; then compounds 3 and 2 (each within the scatter of the next).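

In this assay, within the data shown here, trifluoromethyl in place of fluoro on the ring gives a 2.0-fold lower number from compound 2 to compound 3 (0.30 log units; within the scatter), the first direct reading on this change, and it shows that four heavy atoms can stand where one stood without a step beyond the scatter. Placing 3-(trifluoromethyl)phenyl where compound 1 carries 2-methylprop-1-en-1-yl gives a 2.2-fold higher number from compound 1 to compound 3 (0.34 log units; beyond the scatter), so both ring-bearing groups shown, the fluoro one and the trifluoromethyl one, give higher numbers than compound 1. No measurement is available that bears on why the numbers fall this way.

The compounds shown leave open whether the ring needs any group at this place. They also leave open whether a methoxy group or an amine there, or a longer chain in place of the 3-fluorobenzyl, would move the number beyond the scatter.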